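This account rests on a few compounds, and the source may have more. Where it says the series, first, only, none or still open, it means among the compounds named here.

Of the compounds shown here, three built on one shared core have been measured in a functional assay on NCI-H460 cells (Homo sapiens) for antiproliferative activity, read by MTT assay, with a stated time of 72 h; a lower number here means a stronger inhibitor, a higher number a weaker inhibitor. Compound 2 `CCCNC(=O)c1cc(Oc2ccc(NC(=O)c3cc4cccnc4n(-c4ccccc4)c3=O)cc2)ccn1` gives 110 nM, the lowest number of the three. Compound 3 `CCCNC(=O)c1cc(Oc2ccc(NC(=O)c3cc4cccnc4n(-c4ccc(Br)cc4)c3=O)cc2)ccn1` gives 620 nM, the second highest of the three numbers. Compound 1 `CNC(=O)c1cc(Oc2ccc(NC(=O)c3cc4cccnc4n(-c4ccc(C(F)(F)F)cc4Cl)c3=O)cc2)ccn1` gives 2110 nM, the highest of the three. For the measured compounds named here, only one single-point change has been measured among them: a 5.6-fold higher number from compound 2 to compound 3 (0.75 log units; beyond the scatter), a step that lies beyond the scatter and points toward a weaker inhibitor.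

Compound 4 `CCCNC(=O)c1cc(Oc2ccc(NC(=O)c3cc4cccnc4n(-c4ccc(C(F)(F)F)cc4Cl)c3=O)cc2)ccn1` has not yet been measured. It differs from compound 3 by 2-chloro-4-(trifluoromethyl)phenyl in place of 4-bromophenyl on an aromatic nitrogen. Going by the values given here, no measured step covers this exact exchange. Two observations bear on it. First, the measured step of a 5.6-fold higher number from compound 2 to compound 3 (0.75 log units; beyond the scatter) shows that placing a group on that phenyl ring raised the number. Second, the same 2-chloro-4-(trifluoromethyl)phenyl as in compound 4, on a molecule that differs from it elsewhere, is carried by compound 1, which gives 2110 nM, the highest number seen so far. The number for compound 4 is therefore expected to rise relative to compound 3, by about a 2.4-fold higher number from compound 3 to compound 4 (0.38 log units; beyond the scatter). The estimate for compound 4 in this assay is 1500 nM, with a likely range from 500 nM to 4500 nM.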

Compound 4, half-maximal inhibitory concentration: 3170 nM
Compound 4: the middle estimate sits 2.1-fold (0.32 log units) below what was measured, within the range that was stated.
By their numbers in this assay, from the lowest: compound 2; then compound 3; then compounds 1 and 4 (each within the scatter of the next).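

In this assay, the group on the aromatic nitrogen has more effect than the bromo step alone showed: 2-chloro-4-(trifluoromethyl)phenyl in place of 4-bromophenyl gives a 5.1-fold higher number from compound 3 to compound 4 (0.71 log units; beyond the scatter), and the same group in place of plain phenyl gives a 29-fold higher number from compound 2 to compound 4 (1.46 log units; beyond the scatter). Among these compounds, then, both substituted phenyl groups point toward a weaker inhibitor, and the plain phenyl of compound 2 has the lowest number, with no compound going against this. The chain on the amide nitrogen, by contrast, shows no clear effect with this phenyl group: ethyl in place of hydrogen on that chain gives a 1.5-fold higher number from compound 1 to compound 4 (0.18 log units; within the scatter), which lies within the scatter, and nothing measured here explains either result.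

Chlorine and trifluoromethyl enter together, so the compounds shown cannot tell whether one of them alone accounts for the rise or both contribute. Also open, as far as these compounds go, is whether a methoxy group or an amine on that phenyl ring would keep the number close to that of compound 2, and whether the chain would matter any more with a plain phenyl ring.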